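The compounds below may be only part of what the source reports. "The series", "measured", "known", "first", "only" and "open" are said of these compounds alone.

Of the compounds shown here, three of one series have been measured in an assay on HEK293 cells for inhibition of acid ceramidase (Homo sapiens), with a stated time of 10 min; a lower number here means a stronger inhibitor, a higher number a weaker inhibitor. Compound 1 `O=C(NCCCCc1ccccc1)n1c(=O)oc2ccc(Br)cc21` gives 22 nM, compound 2 `O=C(c1ccc(Cl)cc1)c1ccc2c(c1)oc(=O)n2C(=O)NCCCCc1ccccc1` gives 14 nM, and compound 3 `O=C(NCCCCCCc1ccccc1)n1c(=O)oc2ccccc21` gives 51 nM. Compound 2 has the lowest number of the three; its value and that of compound 1 lie within the scatter of each other, while compound 3 sits beyond the scatter above it. Compound 4 `O=C(NCCCCc1ccccc1)n1c(=O)oc2cc(Cl)ccc21` has not yet been measured. It differs from compound 2 in one place: chloro in place of (4-chlorophenyl)carbonyl on an aromatic carbon. Because compound 1, which also carries a single halogen on the shared core, gives 22 nM, only a modest shift toward a higher number is expected for compound 4 in this assay, near the edge of the scatter. Compound 4 is therefore estimated at 30 nM, between 10 nM and 90 nM, a step of a 2.1-fold higher number from compound 2 to compound 4 (0.33 log units; beyond the scatter) that is expected.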

Compound 4, half-maximal inhibitory concentration: 33 nM
The estimate for compound 4 lay 1.1-fold (0.04 log units) below the measured number; measured number inside the range.
By their numbers in this assay, from the lowest: compounds 2, 1, 4 and 3 (each within the scatter of the next, the first and the last beyond it).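

In this assay, the change gives a 2.4-fold higher number from compound 2 to compound 4 (0.37 log units; beyond the scatter), a modest step beyond the scatter. This shows that on this aromatic carbon the (4-chlorophenyl)carbonyl group, with its six-membered aromatic ring and carbonyl, can give way to a lone chloro at only a modest cost, and compound 4 still gives 33 nM. Nothing measured here explains the step.

The compounds shown leave open how an amine, a methoxy group or an unsubstituted benzoyl group would fare on this carbon. They also leave open whether the step holds with a longer chain on the amide.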